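The source may hold more compounds than are shown below. What is called first, only, known or untested is meant among the compounds shown, and "the series" means these compounds.

Measured compounds in this series:
compound 1 `CC(C)C[C@H](N)c1cc(C(F)(F)F)ccc1N1CCN(C(=O)C(C)Cc2ccc(Cl)cc2O)CC1` — 36 nM
compound 2 `CC(C)C[C@H](N)c1cc(C(F)(F)F)ccc1N1CCN(C(=O)COc2cccc(Cl)c2Cl)CC1` — 2500 nM

Within the data shown here, in an assay on HEK293 cells for displacement of a labelled ligand from Melanocortin receptor 4 (Homo sapiens) (a higher number here means a weaker inhibitor, a lower number a stronger inhibitor), compound 2 stands at the higher of the two numbers, its only neighbour being compound 1. Among the measured compounds shown here, the single measured step, a 69-fold higher number from compound 1 to compound 2 (1.84 log units; beyond the scatter), replaces the whole group on the carbonyl carbon and does not touch the aryl ring on the oxygen.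

Compound 3 `CC(C)C[C@H](N)c1cc(C(F)(F)F)ccc1N1CCN(C(=O)COc2ccc([N+](=O)[O-])cc2)CC1` differs from compound 2 by 4-nitrophenyl in place of 2,3-dichlorophenyl on an oxygen on a saturated carbon. For the measured compounds named here, no measured step bears on this swap, so the expectation rests on compound 2 alone: no step beyond the scatter is expected, no change at the digits printed from compound 2 to compound 3 (within the scatter), with wide uncertainty. Compound 3 is estimated at 2500 nM, within 500 nM to 12000 nM.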

Compound 3, inhibition constant: 3100 nM
Compound 3: the middle estimate sits 1.2-fold (0.09 log units) below what was measured; low and high end bracket the measured number.
By their numbers in this assay, from the lowest: compound 1; then compounds 2 and 3 (each within the scatter of the next).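

In this assay, 4-nitrophenyl on the oxygen in place of 2,3-dichlorophenyl gives a 1.2-fold higher number from compound 2 to compound 3 (0.09 log units; within the scatter), so these two aryl groups, which share no ring substituent, are not told apart here. The large gap to the 1-(4-chloro-2-hydroxybenzyl)ethyl group holds with this second aryl group too, at an 86-fold higher number from compound 1 to compound 3 (1.94 log units; beyond the scatter). No evidence on hand bears on these results.

As far as these compounds go, whether an amine or a carboxylic acid on this aryl ring would read differently stays open. Also open, from the compounds shown here alone, is which part of the group on the carbonyl carbon carries the gap to compound 1, since the chain oxygen, the methyl branch and the ring hydroxyl all differ together.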